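Adding a methyl to the benzyl ring of compound 1

The compounds below may be only part of what the source reports. "The series", "measured", "known", "first", "only" and "open" are said of these compounds alone.

Measured in a functional assay on HCT-116 cells (Homo sapiens) for inhibition, read by CCK-8 assay, with a stated time of 48 h (a lower number here means a stronger inhibitor, a higher number a weaker inhibitor), as follows:
- compound 1 `COc1ccc(CN(C(=O)CSC(=S)N2CCN(C(=O)OC(C)(C)C)CC2)c2cc(OC)c(OC)c(OC)c2)cc1` gives 620 nM
- compound 2 `COc1ccc(CN(C(=O)CSC(=S)N2CCN(Cc3ccc(C(C)(C)C)cc3)CC2)c2cc(OC)c(OC)c(OC)c2)cc1` gives 6890 nM
- compound 3 `COc1ccc(CN(C(=O)CSC(=S)N2CCN(C(=O)OC(C)(C)C)CC2)c2ccc(OC)cc2)cc1` gives > 20000 nM (a limit of the assay, not a number)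

Compound 1 has the lower of the two actual numbers, with compound 2 the nearest. Compound 4 `COc1ccc(CN(C(=O)CSC(=S)N2CCN(C(=O)OC(C)(C)C)CC2)c2cc(OC)c(OC)c(OC)c2)cc1C` differs from compound 1 by methyl in place of hydrogen on an aromatic carbon and turns 4-methoxybenzyl into 4-methoxy-3-methylbenzyl. Two measured steps start from compound 1, and both are large. Placing 4-(tert-butyl)benzyl in the position of tert-butoxycarbonyl on the ring amine nitrogen gives an 11-fold higher number from compound 1 to compound 2 (1.05 log units; beyond the scatter) and placing 4-methoxyphenyl in the position of 3,4,5-trimethoxyphenyl on the amide-type nitrogen gives an at least 32-fold higher number from compound 1 to compound 3 (1.50 log units; beyond the scatter) in the same direction. Going by the values given here, neither step touches the 4-methoxybenzyl group, and no measured compound varies it, so they bear on compound 4 only indirectly. Both replace a whole group elsewhere, whereas here only a methyl enters. Among the compounds with values here, no large step is therefore expected, and any drift is expected toward a higher number, starting from compound 1 at 620 nM in this assay as the reference. The expected change is a 1.3-fold higher number from compound 1 to compound 4 (0.11 log units; within the scatter) and is not expected to exceed the scatter. The estimate for compound 4 is 800 nM with an expected range from 250 nM to 2800 nM.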

Compound 4, half-maximal inhibitory concentration: > 20000 nM
Compound 4 was reported as a limit; the forecaster's own chance of this, stated with the estimate: 3%; at least 25-fold (1.39 log units) between middle value and limit.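

In this assay compound 4 gives > 20000 nM, a limit of the assay and not a number, so the true size of the change at this position stays unread: the limit of > 20000 nM in this assay, at which 2 of the 4 values shown sit.

The 4-methoxybenzyl group was constant in compounds 1, 2 and 3, and so its tolerance for change could not be judged from them; the new result gives an at least 32-fold higher number from compound 1 to compound 4 (1.50 log units; beyond the scatter), beyond the scatter, for methyl in place of hydrogen on an aromatic carbon ortho to a methoxy group. The earlier large steps each exchanged a whole group, whereas this one adds 1 heavy atom, so in this series a large step in this assay does not require a large structural change, and the 4-methoxybenzyl group joins the two places varied in compound 2 and compound 3 as one where compound 1 does not tolerate every change.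

From the compounds shown here alone, whether this outcome is specific to methyl remains open, as fluorine, chlorine or a hydroxyl group on the same aromatic carbon would test that directly. Also open, going by these compounds, is whether the same methyl would be tolerated on another carbon of this ring, or whether a 4-ethoxybenzyl group in place of 4-methoxybenzyl would keep the value of compound 1.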